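Sulfur-for-oxygen change on the carbinol-bearing pyridine

The compounds below may be only part of what the source reports. "The series", "measured", "known", "first", "only" and "open" are said of these compounds alone.

Measured compounds in an ADME assay on microsomes from liver (Homo sapiens) for metabolic stability; on this read-out lower numbers stand for slow clearance and higher numbers for fast clearance:
compound 1 `CCOc1cc([C@](O)(CCN(C)C)[C@@H](c2cc3cc(Br)ccc3nc2OC)c2cccc(OC)c2F)cc(OC)n1` gives 4.1 uL/min
compound 2 `CCOc1cc([C@](O)(CCN(C)C)[C@@H](c2cc3cc(Br)ccc3nc2OC)c2ccnc(OC)c2OC)cc(OC)n1` gives 3.8 uL/min
compound 3 `COc1cc([C@](O)(CCN(C)C)[C@@H](c2cc3cc(C#N)ccc3nc2OC)c2cccc(C)c2F)cc(OC(F)F)n1` gives 0.6 uL/min

Compound 1 stands highest of the three numbers in this assay: compound 2 sits within the scatter of it, while compound 3 lies furthest, below it beyond the scatter. Compound 4 `COc1cccc([C@H](c2cc3cc(Br)ccc3nc2OC)[C@@](O)(CCN(C)C)c2cc(SC)nc(SC)c2)c1F` is not yet measured. It differs from compound 1 by a group of 10 heavy atoms (7 carbon, 1 nitrogen, 2 sulfur; one six-membered aromatic ring with 1 hetero atom) in place of a group of 11 heavy atoms (8 carbon, 1 nitrogen, 2 oxygen; one six-membered aromatic ring with 1 hetero atom), on a saturated chain carbon bound to an oxygen on a saturated carbon and two saturated chain carbons. Within the data shown here, no measured step touches this position: the one single-point step, a 1.1-fold lower number from compound 1 to compound 2 (0.03 log units; within the scatter), concerns the other aryl group and lay within the scatter, and compound 3 differs from compound 1 in several places at once. Among the measured compounds shown here, with no step that bears on the change, no movement beyond the scatter is expected; the expected step is a 1.2-fold higher number from compound 1 to compound 4 (0.09 log units; within the scatter). For compound 4 the estimate in this assay is 5 uL/min, with a range from 2 uL/min to 14 uL/min.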

Compound 4, intrinsic clearance in a liver preparation (reported as CLH), per the amount of preparation that the assay uses: 3.4 uL/min
Compound 4: middle estimate off by 1.5-fold (0.17 log units), on the high side, and the stated range covers the measured number.
By their numbers in this assay, from the lowest: compound 3; then compounds 4, 2 and 1 (each within the scatter of the next).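

In this assay, placing the sulfur-bearing group of 10 heavy atoms on the saturated chain carbon gives a 1.2-fold lower number from compound 1 to compound 4 (0.08 log units; within the scatter), the first step read at this position. Replacing both oxygens with sulfur on this aromatic ring therefore leaves the clearance number within the scatter in this one pair. No data on the cause of this result are available. Still open, on these data alone, is whether the result carries over to the 2,3-dimethoxypyridin-4-yl series of compound 2, and how an amine or a carboxylic acid on this ring would read.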